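The source may hold more compounds than are shown below. What is called first, only, known or untested is meant among the compounds shown, and "the series" means these compounds.

Measured so far in a functional assay on NCI/ADR-RES cells (Homo sapiens) for inhibition, read by sulforhodamine B assay, with a stated time of 48 h; on this read-out lower numbers stand for stronger inhibition of growth and higher numbers for weaker inhibition of growth:

compound 1 `CC1=CC[C@H](C(C)(C)NC(=S)N/N=C/c2ccc(O)cc2)CC1` gives > 100000 nM, which is a limit of the assay.
compound 2 `COc1cc(/C=N/NC(=S)NC(C)(C)[C@H]2CC=C(C)CC2)ccc1O` gives > 100000 nM, which is a limit of the assay.
compound 3 `CC1=CC[C@H](C(C)(C)NC(=S)N/N=C/c2cccc([N+](=O)[O-])c2)CC1` gives > 100000 nM, which is a limit of the assay.

Compound 1 therefore stands at the limit of this assay, and nothing places it above or below the other two; all three values are of the same kind, as the limit of > 100000 nM in this assay, at which 3 of the 3 values shown sit, records. Among the measured compounds shown here, the one change measured within a single position, methoxy in place of hydrogen on an aromatic carbon, is the step from compound 1 to compound 2, a step that the two limits leave unreadable from compound 1 to compound 2, and it reads as no number at all.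

Compound 4 `CC1=CC[C@H](C(C)(C)NC(=S)N/N=C/c2cccs2)CC1` differs from compound 1 by thiophen-2-yl in place of 4-hydroxyphenyl on a carbon with a double bond to nitrogen. For the measured compounds named here, no measured step touches the aromatic group on that carbon, so the only guide is that every compound of the series so far, compounds 1, 2 and 3, sits at the limit. On that basis compound 4 is expected to sit there too, the step from compound 1 to compound 4 being estimated as a step that the limit leaves unreadable from compound 1 to compound 4, that is, no step beyond the scatter. The estimate for compound 4 in this assay is 150000 nM, with an expected range from 50000 nM to 500000 nM.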

Compound 4, concentration for total growth inhibition: 41000 nM
Beside the measured number, compound 4's estimate is 3.7-fold (0.56 log units) above it, and the stated range ends above it.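

In this assay, among the compounds shown here, thiophen-2-yl in place of 4-hydroxyphenyl on a carbon with a double bond to nitrogen gives an at least 2.4-fold lower number from compound 1 to compound 4 (0.38 log units; beyond the scatter) and is the first readable step. On these data alone, the true size of this step stays open, as the value of compound 1 is a limit, but the aromatic group at this position can now be seen to shift the read-out. Compound 4 alone leaves the limit, which still holds most of the series: the limit of > 100000 nM in this assay, at which 3 of the 4 values shown sit.

The compounds shown do not separate the role of the sulfur-containing five-membered ring from the loss of the hydroxyl, which furan-2-yl or unsubstituted phenyl at the same position would address. As far as these compounds go, the effect on the read-out of changing the rest of the core, for example with an amine or a longer chain, also remains open.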